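Pyrazole chalcones: trimming one methoxy from compound 2

This account rests on a few compounds, and the source may have more. Where it says the series, first, only, none or still open, it means among the compounds named here.

Going by the values given here, compound 2 `COc1cc(-c2cc(/C=C/C(=O)c3ccc(N)cc3)[nH]n2)cc(OC)c1OC` sits second highest of the three numbers so far in a functional assay on SN12C cells (Homo sapiens) for inhibition, read by sulforhodamine B assay, with a stated time of 48 h (a lower number here means that less compound is tolerated, a higher number that more compound is tolerated), at 13400 nM. Its nearest neighbour is compound 3 `COc1ccc(C(=O)/C=C/c2cc(-c3cc(OC)c(OC)c(OC)c3)n[nH]2)cc1OC`, which gives 6370 nM; the furthest is compound 1 `COc1ccc(-c2cc(/C=C/C(=O)c3ccc(N)cc3)[nH]n2)cc1`, which gives 34900 nM. Compound 4 `COc1ccc(-c2cc(/C=C/C(=O)c3ccc(N)cc3)[nH]n2)cc1OC` is obtained from compound 2 by hydrogen in place of methoxy on an aromatic carbon.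

Among the compounds with values here, no measured step matches this change directly. Within the data shown here, the one step on record, a 2.1-fold lower number from compound 2 to compound 3 (0.32 log units; beyond the scatter), concerns the other end of the molecule and does not bear on the methoxy count of the aryl on the pyrazole. Compound 1 and compound 2 differ in two places, so only their two values can be compared: fewer methoxy groups on that aryl went with a higher number. On that basis compound 4 is expected to land between them, closer to compound 2, with an estimated step of a 1.5-fold higher number from compound 2 to compound 4 (0.17 log units; within the scatter) in this assay. Compound 4 is therefore estimated at 20000 nM, in the range 9000 nM to 45000 nM.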

Compound 4, concentration lethal to 50% of the cells: 41300 nM
Estimate against measurement, compound 4: 2.1-fold (0.31 log units) below, and the stated range covers the measured number.
By their numbers in this assay, from the lowest: compound 3; then compound 2; then compounds 1 and 4 (each within the scatter of the next).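

In this assay, hydrogen in place of the methoxy group lying ortho to a methoxy group gives a 3.1-fold higher number from compound 2 to compound 4 (0.49 log units; beyond the scatter) and so shows, in a single change, that this methoxy group matters to the number. The other single methoxy change on the same aryl gives a 1.2-fold higher number from compound 1 to compound 4 (0.07 log units; within the scatter) and stays within the scatter, so among compounds 1, 2 and 4 only compound 2 stands apart, and the two methoxy steps are not equal. Nothing measured here accounts for that difference.

On these data alone, whether a hydroxyl group or a fluorine atom on that carbon would keep the lower number of compound 2 remains open. Also open, as far as these compounds go, is whether the same step holds with the 3,4-dimethoxyphenyl of compound 3 in place of the 4-aminophenyl.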